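A few compounds are considered here, and "the series" means these few. Any claim that something is new, unique, unknown or untested is made for them only; others in the source may bear on it.

The measured compounds in a functional assay (Cavia porcellus) for antagonist activity at Serotonin 3 (5-HT3) receptor (Homo sapiens); a higher number here means a weaker inhibitor, a lower number a stronger inhibitor:

compound 1 `Cc1[nH]cnc1CN1CCN(c2cccc(Br)c2)C1=O`: compound 1 gives 10.4 nM
compound 2 `Cc1[nH]cnc1CN1CCN(c2cccc(C#N)c2)C1=O`: compound 2 gives 134 nM

Within the data shown here, compound 2 stands at the highest of the two numbers; its nearest neighbour is compound 1, and the step of a 13-fold higher number from compound 1 to compound 2 (1.11 log units; beyond the scatter) is the only measured step available. Compound 3 `Cc1cccc(N2CCN(Cc3nc[nH]c3C)C2=O)c1` is not yet measured in this assay. Among the measured compounds shown here, the change from compound 2 to compound 3 is methyl in place of cyano on an aromatic carbon, so it alters the same position of the shared core that the one measured step touched. That step was large, showing that this position bears strongly on the result in this assay. For the measured compounds named here, because of a 13-fold higher number from compound 1 to compound 2 (1.11 log units; beyond the scatter) the number for compound 3 is expected to move away from that of compound 2, since the only step known changed the outcome well beyond the scatter; yet nothing measured shows where a methyl would land, so the expected step of a 5.4-fold lower number from compound 2 to compound 3 (0.73 log units; beyond the scatter) is taken as a substantial fall with wide uncertainty. Compound 3 is therefore estimated at 25 nM in this assay, with a range from 8 nM to 80 nM.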

Compound 3, antagonist equilibrium constant: 45.7 nM
Compound 3: the middle estimate sits 1.8-fold (0.26 log units) below what was measured; measured number inside the range.
By their numbers in this assay, from the lowest: compound 1; then compound 3; then compound 2.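

In this assay, among these compounds, a third group on this aromatic carbon turns the single earlier comparison into an order of three: a 2.9-fold lower number from compound 2 to compound 3 (0.47 log units; beyond the scatter) and a 4.4-fold higher number from compound 1 to compound 3 (0.64 log units; beyond the scatter) place methyl between cyano and bromo. Each of these steps lies beyond the scatter, so the three groups stand apart, and the large gap seen in a 13-fold higher number from compound 1 to compound 2 (1.11 log units; beyond the scatter) resolves into two modest steps rather than one group differing sharply from all others at this position. Compound 1 remains the strongest inhibitor of the three, and nothing presented here accounts for this order.

The compounds shown leave open whether any other group at this place could give a lower number than compound 1 does with 10.4 nM, since only three groups have been compared and they offer no basis for extrapolating to others. Going by these compounds, how a chloro or methoxy group, or an amine, would fall relative to methyl, bromo and cyano remains unknown, as does whether the same order would hold if the shared core were changed elsewhere.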